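From 2,3-dichlorophenyl to 2,3-dimethoxyphenyl: an expected step back

The compounds below may be only part of what the source reports. "The series", "measured", "known", "first", "only" and "open" are said of these compounds alone.

In a functional assay on HCT-116 cells (Homo sapiens) for antiproliferative activity, read by sulforhodamine B assay, with a stated time of 48 h (on this read-out lower numbers stand for stronger inhibition and higher numbers for weaker inhibition), compound 3 (`COc1cc(OC)c(C(=O)/C=C/c2cccc(Cl)c2Cl)c(OCC=C(C)C)c1`) gives 1900 nM as its value. That lies within the scatter of compound 1 (`COc1cc(O)c(C(=O)/C=C/c2cccc(OC)c2OC)c(OC)c1`) at 3500 nM and clearly under compound 2 (`COc1cc(OC)c(C(=O)/C=C/c2ccc(OC)c(OC)c2)c(OCC=C(C)C)c1`) at 5700 nM in these notes. Compound 4 (`COc1cc(OC)c(C(=O)/C=C/c2cccc(OC)c2OC)c(OCC=C(C)C)c1`) differs from compound 3 by one change (2,3-dimethoxyphenyl in place of 2,3-dichlorophenyl on a double-bonded chain carbon bound to a double-bonded chain carbon) on a double-bonded chain carbon bound to a double-bonded chain carbon. Within the data shown here, the only measured step at this place is a 3.0-fold lower number from compound 2 to compound 3 (0.48 log units; beyond the scatter) and it replaced 3,4-dimethoxyphenyl, not 2,3-dimethoxyphenyl, with 2,3-dichlorophenyl. Compound 1 also carries 2,3-dimethoxyphenyl and gives 3500 nM but differs elsewhere on the core. Going back to a dimethoxyphenyl is therefore expected to raise the number in this assay by less than that measured step. The estimated step is a 1.9-fold higher number from compound 3 to compound 4 (0.28 log units; within the scatter) as the working expectation. For compound 4 the estimated value is 3600 nM with an expected range from 1700 nM to 7500 nM in this read-out.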

Compound 4, half-maximal inhibitory concentration: 11700 nM
For compound 4 the middle estimate is 3.3-fold (0.51 log units) below the measured one, outside the stated range (above it).
By their numbers in this assay, from the lowest: compounds 3, 1 and 2 (each within the scatter of the next, the first and the last beyond it); then compound 4.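

In this assay, 2,3-dimethoxyphenyl in place of 2,3-dichlorophenyl gives a 6.2-fold higher number from compound 3 to compound 4 (0.79 log units; beyond the scatter), so the dichlorophenyl group holds its lower number against this dimethoxyphenyl group as well as against 3,4-dimethoxyphenyl. The two dimethoxyphenyl groups are also not interchangeable at this place: 2,3-dimethoxyphenyl in place of 3,4-dimethoxyphenyl gives a 2.1-fold higher number from compound 2 to compound 4 (0.31 log units; beyond the scatter). With 2,3-dimethoxyphenyl held constant, the oxygen on the aromatic ring also matters, as 3-methylbut-2-en-1-yl in place of hydrogen gives a 3.3-fold higher number from compound 1 to compound 4 (0.52 log units; beyond the scatter).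

Nothing available explains any of these steps. As far as these compounds go, it remains open whether 2,3-dichlorophenyl keeps its lower number on the core of compound 1, and how an aminophenyl or a carboxyphenyl group would behave at this place.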